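Hydroxy on the fused ring system of compound 1

The source may hold more compounds than are shown below. What is called first, only, known or untested is meant among the compounds shown, and "the series" means these compounds.

In a functional assay on COLO 205 cells (Homo sapiens) for inhibition, read by sulforhodamine B assay (a lower number here means a stronger inhibitor of growth, a higher number a weaker inhibitor of growth), compound 1 (`c1ccc(-c2ccc(-c3ccc(-c4nc5ccccc5[nH]4)cc3)cc2)cc1`) gives 100000 nM and stands level with compound 3 (`Clc1cccc(-c2ccc(-c3ccc(-c4nc5ccccc5[nH]4)cc3)cc2)c1`) at 100000 nM as the highest of three numbers, while compound 2 (`COc1ccc(-c2ccc(-c3ccc(-c4nc5ccccc5[nH]4)cc3)cc2)cc1`) gives 45200 nM as the lowest. Compound 4 (`Oc1cccc2[nH]c(-c3ccc(-c4ccc(-c5ccccc5)cc4)cc3)nc12`) differs from compound 1 by hydroxy in place of hydrogen on an aromatic carbon, on a ring that is part of a fused or bridged system of two rings. Methoxy in place of hydrogen gave a 2.2-fold lower number from compound 1 to compound 2 (0.34 log units; beyond the scatter) and chloro in place of hydrogen gave no change at the digits printed from compound 1 to compound 3 (within the scatter) elsewhere on the molecule, so neither is a direct guide. The expected outcome is a 2.2-fold lower number from compound 1 to compound 4 (0.35 log units; beyond the scatter) in this assay as a modest step of about the methoxy size. Compound 4 is expected near 45000 nM with an estimated range of 12000 nM to 100000 nM overall.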

Compound 4, concentration for 50% growth inhibition: 1210 nM
Estimate against measurement, compound 4: 37-fold (1.57 log units) above; measured number below the stated range.
By their numbers in this assay, from the lowest: compound 4; then compound 2; then compounds 1 and 3 (each within the scatter of the next).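

In this assay, hydroxy in place of hydrogen on the six-membered aromatic ring of carbon only, part of the fused system, gives an 83-fold lower number from compound 1 to compound 4 (1.92 log units; beyond the scatter), so this position responds strongly to a single added group. The earlier change elsewhere on the molecule, methoxy in place of hydrogen, gave only a 2.2-fold lower number from compound 1 to compound 2 (0.34 log units; beyond the scatter). Nothing here accounts for the size of the hydroxy step.

The compounds shown leave open whether methoxy or an amine at this same carbon would match hydroxy. They also leave open whether hydroxy on the ring's other carbons would do the same.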